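From Compound 3 to Compound 4: an Expected Step

A few compounds are considered here, and "the series" means these few. Any claim that something is new, unique, unknown or untested is made for them only; others in the source may bear on it.

Of the compounds shown here, three sharing one core have been measured in an ADME assay on DU-145 cells (Homo sapiens) for cytotoxicity, read by MTT assay, with a stated time of 72 h; on this read-out higher numbers stand for weaker inhibition and lower numbers for stronger inhibition. Compound 1, `COc1ccc(C2=C(c3cc(OC)c(OC)c(OC)c3)CC(O)C2=O)cc1[N+](=O)[O-]`, gives only a limit in this assay, > 100 ug/mL. Compound 2, `COc1ccc(C2=C(c3cc(OC)c(OC)c(OC)c3)C(=O)CC2C)cc1C(=O)O`, likewise returns a limit in this assay, > 100 ug/mL. Among the measured compounds shown here, compound 3, `COc1ccc(C2=C(c3cc(OC)c(OC)c(OC)c3)C(=O)CC2O)cc1`, is the one compound with a number: in this assay compound 3 gives 18.7 ug/mL. For the measured compounds named here, compound 3 therefore stands alone as the only numerical value in the set. The other two values sit at the limit of > 100 ug/mL in this assay, at which 2 of the 3 values shown sit.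

The unmeasured compound 4, `CCOC(=O)COc1ccc(C2=C(c3cc(OC)c(OC)c(OC)c3)C(=O)CC2O)cc1`, differs from compound 3 in one place: ethoxycarbonyl in place of hydrogen on a saturated chain carbon bound to an oxygen on an aromatic ring. Going by the values given here, no pair of measured compounds differs in a single place, so no measured step sets a scale for this kind of change, and the two limits give no direction either. Compound 3 and compound 4 share everything else.

Among the compounds with values here, with no measured step to lean on, the expectation rests on compound 3 alone. For the step of a 1.6-fold higher number from compound 3 to compound 4 (0.21 log units; within the scatter) a modest weakening is expected, one not far beyond the scatter. Compound 4 is estimated at 30 ug/mL in this assay, with a range from 10 ug/mL to 100 ug/mL.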

Compound 4, half-maximal inhibitory concentration: > 100 ug/mL
Compound 4: only a limit was reported; the forecaster's own chance of this, stated with the estimate: 25%; middle value at least 3.3-fold (0.52 log units) from the limit.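

Among the compounds shown here, the change from methoxy to (ethoxycarbonyl)methoxy gives the first measured step between two compounds that differ in one place, and in this assay it reads an at least 5.3-fold higher number from compound 3 to compound 4 (0.72 log units; beyond the scatter). Compound 4 gives > 100 ug/mL, which is a limit and not a number, so the step has a lower bound and no upper one. This position is therefore sensitive to the change, since the measurable inhibition of compound 3 is not kept once ethoxycarbonyl stands on the saturated chain carbon bound to an oxygen on an aromatic ring, and compound 4 joins the compounds held at the limit: the limit of > 100 ug/mL in this assay, at which 3 of the 4 values shown sit.

The compounds shown leave open how far beyond the limit compound 4 lies, and whether the loss follows from ethoxycarbonyl itself or from any substituent on that carbon. A carboxylic acid, an amine or a longer plain alkyl chain in the same place would help to separate these readings, and smaller groups there would show whether any change at this position keeps a number in this assay.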